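Shortening the Aniline Side Chain in a Nitroaryl Piperazine Series

The source may report more compounds than this note shows. Statements on the series, on what has been measured and on what is new or still open speak of the compounds shown alone.

Measured so far:
Compound 1, `O=[N+]([O-])c1ccc(N2CCNCC2)cc1NCCOc1ccc(Cl)cc1`, gives 290 nM.
Compound 2, `O=[N+]([O-])c1ccc(N2CCNCC2)cc1NCCOc1ccccc1`, gives 114 nM.

Going by the values given here, in an assay on HEK293 cells for displacement of a labelled ligand from 5-hydroxytryptamine receptor 6 (Homo sapiens) (a higher number here means a weaker inhibitor, a lower number a stronger inhibitor), compound 2 stands lowest of the two numbers, and the only neighbour is compound 1, which lies higher, as the step from chloro to hydrogen shows: a 2.5-fold lower number from compound 1 to compound 2 (0.41 log units; beyond the scatter).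

Compound 3, `O=[N+]([O-])c1ccc(N2CCNCC2)cc1NCc1ccc(Cl)cc1`, has not yet been measured. It differs from compound 2 in one place: 4-chlorophenyl in place of phenoxymethyl on a saturated chain carbon bound to a nitrogen on an aromatic ring. This change has two parts. Among the compounds with values here, the chloro returns to the aromatic ring, and here the one measured step bears on it, since removing that chloro gave a 2.5-fold lower number from compound 1 to compound 2 (0.41 log units; beyond the scatter), so putting it back might be expected to raise the number by a modest amount. Within the data shown here, the second part, the loss of the oxygen and one chain carbon between the aromatic ring and the nitrogen, has no counterpart among the measured compounds, and its effect is unknown in either direction.

Taking the chloro step as the only guide and allowing wide room for the shortened chain, compound 3 is expected to give 400 nM, within 100 nM to 1600 nM. Relative to compound 2 this is an estimated 3.5-fold higher number from compound 2 to compound 3 (0.55 log units; beyond the scatter).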

Compound 3, inhibition constant: 8 nM
Estimate against measurement, compound 3: 50-fold (1.70 log units) above; measured number below the stated range.
By their numbers in this assay, from the lowest: compound 3; then compound 2; then compound 1.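

In this assay the exchange of phenoxymethyl for 4-chlorophenyl on a saturated chain carbon bound to a nitrogen on an aromatic ring gave a 14-fold lower number from compound 2 to compound 3 (1.15 log units; beyond the scatter) and so showed that this position can move the number much further than the modest earlier step, a 2.5-fold lower number from compound 1 to compound 2 (0.41 log units; beyond the scatter) on removal of the chloro, had revealed. That earlier step alone had tied the chloro to a higher number, yet compound 3 carries a chloro and has the lowest number of the three, so the chloro does not raise the number in every setting shown here. No evidence is available on why the number fell so far, and the result stands as an observation only.

The step combines the loss of the oxygen, the shorter chain and the return of the chloro, and the compounds shown do not separate these parts; a plain phenyl in place of the 4-chlorophenyl would begin to do so. Also open, from the compounds shown here alone, is how the number would respond to fluoro or methoxy in place of the chloro, or to a chain of the earlier length without its oxygen.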